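A few compounds are considered here, and "the series" means these few. Any claim that something is new, unique, unknown or untested is made for them only; others in the source may bear on it.

Measured in a physicochemical assay for solubility, at pH 6.8; on this read-out higher numbers stand for higher solubility and lower numbers for lower solubility:
compound 1 `COC[C@H]1CCCN(c2ccnc3sc(C(N)=O)c(N)c23)C1`: 220 ug/mL
compound 2 `CCOCCOC[C@H]1CCCN(c2cc(C)nc3sc(C(N)=O)c(N)c23)C1`: 560 ug/mL

Compound 2, at 560 ug/mL, holds the higher of the two numbers, and its gap to compound 1, at 220 ug/mL, lies beyond the scatter. Compound 3 `CCOCCOC[C@H]1CCCN(c2ccnc3sc(C(N)=O)c(N)c23)C1` carries hydrogen in place of methyl on an aromatic carbon of compound 2 (hydrogen in place of methyl on an aromatic carbon). Among the measured compounds shown here, no measured pair isolates this change. In this assay, no step beyond the scatter is expected. The estimated step is a 1.1-fold lower number from compound 2 to compound 3 (0.05 log units; within the scatter). For compound 3 the expected value is 500 ug/mL, with an estimated range of 220 ug/mL to 1100 ug/mL.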

Compound 3, solubility: 500 ug/mL
For compound 3 middle estimate and measured number coincide at the digits printed, within the range that was stated.
By their numbers in this assay, from the lowest: compound 1; then compounds 3 and 2 (each within the scatter of the next).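

In this assay hydrogen in place of methyl on this aromatic carbon gives a 1.1-fold lower number from compound 2 to compound 3 (0.05 log units; within the scatter) and so separates the two groups by no more than the scatter. Compound 3 also isolates ethoxymethyl in place of hydrogen on a saturated chain carbon bound to an oxygen on a saturated carbon, with a 2.3-fold higher number from compound 1 to compound 3 (0.36 log units; beyond the scatter) as a single change. Compound 1 and compound 2 alone could not separate this change from the methyl. Nothing at hand bears on the origin of either step. Open, from the compounds shown here alone, is whether an amine or a carboxylic acid on this aromatic carbon would also stay within the scatter, and whether a longer chain would go beyond the ethoxymethyl step.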